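This account rests on a few compounds, and the source may have more. Where it says the series, first, only, none or still open, it means among the compounds named here.

Measured compounds:
compound 1 `CCCc1nnsc1CO/N=C/c1c(C)nn(C)c1Oc1ccccc1Cl` in a functional assay on Huh-7 cells (Homo sapiens) for inhibition, read by MTT assay, with a stated time of 48 h; on this read-out lower numbers stand for stronger inhibition and higher numbers for weaker inhibition: compound 1 gives > 50000 nM.
compound 2 `CCCc1nnsc1CO/N=C/c1c(C)nn(C)c1Oc1ccc(F)cc1` in this assay: compound 2 gives > 50000 nM.

The value of compound 2 is a limit of the assay, not a number. The value of compound 1 is likewise a limit. Compound 2 thus stands at the limit of > 50000 nM in this assay, at which 2 of the 2 values shown sit. The step that the two limits leave unreadable from compound 1 to compound 2 cannot be read. Compound 3 `CCCc1nnsc1CO/N=C/c1c(C)nn(C)c1Oc1ccc(Cl)cc1` differs from compound 2 by chloro in place of fluoro on an aromatic carbon. Within the data shown here, no measured step bears on this change, and both anchors sit at the limit. Compound 3 is expected to remain at the limit, so the estimated step of a number no higher from compound 2 to compound 3 (the limit leaves the size open) has no readable size. The estimate for compound 3 is 50000 nM, in a range from 20000 nM to 200000 nM.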

Compound 3, half-maximal inhibitory concentration: > 50000 nM
Compound 3 was reported as a limit; the forecaster's own chance of this, stated with the estimate: 80%; the middle value lies on the limit itself.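

Compound 3 also gives a limit and not a number, so no new step can be read among compound 1, compound 2 and compound 3: the limit of > 50000 nM in this assay, at which 3 of the 3 values shown sit. The compounds shown leave open how strongly any of them inhibits, and whether chloro in place of fluoro changes that at all.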